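Changing the aryl group: two fluorines out, an ethyl in

The source may hold more compounds than are shown below. What is called first, only, known or untested is meant among the compounds shown, and "the series" means these compounds.

Compound 1 `COc1ccc(C2=CCN(S(=O)(=O)N3CCCC[C@@H]3C(=O)NO)CC2)cc1`: 15000 nM
Compound 2 `O=C(NO)[C@H]1CCCCN1S(=O)(=O)N1CC=C(c2ccc(F)c(F)c2)CC1`: 1200 nM

Among the measured compounds shown here, in a functional assay on MONO-MAC-6 cells (Homo sapiens) for inhibition (on this read-out higher numbers stand for weaker inhibition and lower numbers for stronger inhibition), compound 2 gives the lowest of the two numbers, and the gap to its only neighbour is large: a 13-fold lower number from compound 1 to compound 2 (1.10 log units; beyond the scatter). Compound 3 `CCc1cccc(C2=CCN(S(=O)(=O)N3CCCC[C@@H]3C(=O)NO)CC2)c1` differs from compound 2 by 3-ethylphenyl in place of 3,4-difluorophenyl on a double-bonded ring carbon. For the measured compounds named here, only one measured step bears on this, a 13-fold lower number from compound 1 to compound 2 (1.10 log units; beyond the scatter), and it shows that what sits on the aryl ring matters greatly, yet no measured pair swaps fluorines for an ethyl group. Compound 3 is therefore expected to fall between its two neighbours, estimated at 4000 nM with a range from 1000 nM to 15000 nM. That amounts to an expected 3.3-fold higher number from compound 2 to compound 3 (0.52 log units; beyond the scatter).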

Compound 3, half-maximal inhibitory concentration: 320 nM
Beside the measured number, compound 3's estimate is 13-fold (1.10 log units) above it, and the stated range ends above it.
By their numbers in this assay, from the lowest: compound 3; then compound 2; then compound 1.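

In this assay, the best aryl group so far carries neither fluorine nor methoxy: 3-ethylphenyl in place of 3,4-difluorophenyl still lowers the number beyond the scatter (a 3.8-fold lower number from compound 2 to compound 3 (0.57 log units; beyond the scatter)), and the change from 4-methoxyphenyl is far larger (a 47-fold lower number from compound 1 to compound 3 (1.67 log units; beyond the scatter)). Two aryl groups with the same count of heavy atoms therefore still differ clearly, so this position responds to more than group size. Nothing measured here explains why the ethyl group does better. Open questions are whether a longer chain such as propyl, or an amine on the aryl ring, would lower the number further, and whether the ethyl group's effect depends on where it sits on that ring.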